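The compounds below may be only part of what the source reports. "The series", "measured", "known", "first", "only" and "open" are said of these compounds alone.

Measured so far:
Compound 1, `C[n+]1ccn(CCCCC#N)c1/C=N/O`, with -2.8.
Compound 2, `C[n+]1ccn(COCCCBr)c1/C=N/O`, with -1.76.
Compound 3, `C[n+]1ccn(CC[N+](=O)[O-])c1/C=N/O`, with no result reported.

In a physicochemical assay for lipophilicity (a higher number here means a more lipophilic compound, a lower number a more polar compound), compound 1 gives -2.8 and compound 2 gives -1.76, so in this assay the pair shows a number 1.04 log units higher from compound 1 to compound 2 (beyond the scatter). Compound 3 was run in this assay, but no number came out of the measurement, so its position rests on nothing more than the shared core it has with the other two compounds. Compound 4, `C[n+]1ccn(CCS(C)(=O)=O)c1/C=N/O`, differs from compound 3 in one place: methylsulfonyl in place of nitro on a saturated chain carbon, two bonds along the chain from an aromatic nitrogen. For the measured compounds named here, the only measured step in this assay, from compound 1 to compound 2, concerns a different change at the end of the chain, and no measured pair in this assay compares a nitro group with a methylsulfonyl group. There is therefore nothing that sets the direction or size of the step from compound 3 to compound 4 in this assay. Given that compound 1 and compound 2 both sit deep in the polar range, compound 4 is expected to land near -2.7, in an estimated range from -3.5 to -1.9.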

Compound 4, distribution coefficient: -3.5
Estimate against measurement, compound 4: 0.80 log units above; measured number inside the range.
By their numbers in this assay, from the lowest: compound 4; then compound 1; then compound 2.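

With methylsulfonyl two bonds along the chain from an aromatic nitrogen, compound 4 has the lowest number of the three compounds with a result in this assay, with a number 1.74 log units lower from compound 2 to compound 4 (beyond the scatter) and a number 0.70 log units lower from compound 1 to compound 4 (beyond the scatter) as the steps that place it there. These steps show that a short chain ending in methylsulfonyl can sit clearly below both longer chains, although each step also changes the chain itself, so neither isolates the end group. Compound 3 has no number, so the steps from it cannot be read and the change from nitro to methylsulfonyl has no size here, and nothing shown gives a reason for the steps that can be read.

The compounds shown leave open where a chain of the same length ending in an amine or a carboxylic acid would fall in this assay. They also leave open whether methylsulfonyl on a longer chain would keep the number this low.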